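Methoxy for Fluoro on a Paw Edema Series

The source may report more compounds than this note shows. Statements on the series, on what has been measured and on what is new or still open speak of the compounds shown alone.

Three compounds have numbers in a functional assay on the whole organism for inhibition, with Rattus norvegicus as the target, read by paw edema, with stated times of 1 h and 2 h, at a dose of 10 umol/kg by the subcutaneous route; a higher number here means more inhibition at the dose given (going by the name of the read-out), a lower number less inhibition. Compound 1 `N#Cc1cnn(-c2ccc(S(N)(=O)=O)cc2)c1NC(=O)CCl` gives 26.5% in this assay, compound 2 `CC(=O)Nc1c(C#N)cnn1-c1ccc(S(=O)(=O)NC(C)=O)cc1` gives 17.5%, and compound 3 `N#Cc1cnn(-c2ccc(S(N)(=O)=O)cc2)c1/N=C/c1ccc(F)cc1` gives 7.94%. The value of compound 3 is within the scatter of that of compound 2, but stands beyond the scatter from that of compound 1.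

Compound 4 `COc1ccc(/C=N/c2c(C#N)cnn2-c2ccc(S(N)(=O)=O)cc2)cc1` differs from compound 3 in one place: methoxy in place of fluoro on an aromatic carbon. For the measured compounds named here, no pair of measured compounds shows what such a change does in this assay, so the step from compound 3 to compound 4 is expected to be small, in either direction, and not beyond the scatter. The step of a number 2.1 percentage points higher from compound 3 to compound 4 (within the scatter) is the estimate here. Compound 4 is estimated to give 10% in this assay, expected between 0% and 25%.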

Compound 4, a percentage reported as inhibition, in the whole organism at one dose (the size of the read-out at that dose, not a potency): 5.29%
Estimate against measurement, compound 4: 4.7 percentage points above; low and high end bracket the measured number.
By their numbers in this assay, from the lowest: compounds 4, 3, 2 and 1 (each within the scatter of the next, the first and the last beyond it).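

For the compounds shown here, the first pair to test this change at this position gives a number 2.7 percentage points lower from compound 3 to compound 4 (within the scatter) in this assay for 4-fluorophenyl to 4-methoxyphenyl. The two compounds cannot be told apart at this dose, so this swap on the aromatic carbon leaves the inhibition without a readable change. No available evidence explains this result.

On these data alone, whether an amine, a carboxylic acid or a longer chain such as ethoxy at this position would move the number beyond the scatter remains open. So does whether a methoxy for fluoro swap would behave the same way at another place on the ring.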